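Working notes: from compound 3 to compound 4

A few compounds are considered here, and "the series" means these few. Any claim that something is new, unique, unknown or untested is made for them only; others in the source may bear on it.

Values in a functional assay on CHO-K1 cells for antagonist activity at prostaglandin E2 receptor EP1 subtype (Homo sapiens), read by FLIPR; on this read-out higher numbers stand for weaker inhibition and lower numbers for stronger inhibition:
compound 1, `Cc1cc(C(=O)O)nn1Cc1cc(Br)ccc1OCc1ccccc1`: 15.1 nM
compound 2, `Cc1cc(C(=O)O)nn1Cc1cc(Br)ccc1OCc1cccc(Cl)c1`: 427 nM
compound 3, `Cc1cccc(COc2ccc(Br)cc2Cn2nc(C(=O)O)cc2C)c1`: 525 nM

Compound 3 shows the highest number of the three. Its gap to compound 2, a 1.2-fold higher number from compound 2 to compound 3 (0.09 log units; within the scatter), is within the scatter, whereas a 35-fold higher number from compound 1 to compound 3 (1.54 log units; beyond the scatter) lies well beyond it. Compound 4, `Cc1cc(C(=O)O)nn1Cc1cc(Br)ccc1OCc1cccc(C(F)(F)F)c1`, differs from compound 3 by trifluoromethyl in place of methyl on an aromatic carbon. Going by the values given here, two steps bear on this: a 28-fold higher number from compound 1 to compound 2 (1.45 log units; beyond the scatter) and a 35-fold higher number from compound 1 to compound 3 (1.54 log units; beyond the scatter) both show a large rise once a group sits there, and a 1.2-fold higher number from compound 2 to compound 3 (0.09 log units; within the scatter) shows that exchanging one such group for another leaves the number essentially unchanged. A third group at the same place is therefore expected to give no step beyond the scatter, a 1.1-fold higher number from compound 3 to compound 4 (0.06 log units; within the scatter). Compound 4 is estimated at 600 nM, with a range of 200 nM to 2000 nM.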

Compound 4, inhibition constant: 1100 nM
Compound 4: the middle estimate sits 1.8-fold (0.26 log units) below what was measured; the range from low to high includes it.
By their numbers in this assay, from the lowest: compound 1; then compounds 2 and 3 (each within the scatter of the next); then compound 4.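

In this assay this position does not treat all groups alike: trifluoromethyl stands apart from methyl (a 2.1-fold higher number from compound 3 to compound 4 (0.32 log units; beyond the scatter)) and from chloro (a 2.6-fold higher number from compound 2 to compound 4 (0.41 log units; beyond the scatter)), so exchanging one group for another here can move the number beyond the scatter. Those modest steps remain small compared with the step from hydrogen (a 73-fold higher number from compound 1 to compound 4 (1.86 log units; beyond the scatter)), and compound 1 stays lowest of the four. No measured data account for the difference between trifluoromethyl and the other two groups.

From the compounds shown here alone, whether fluoro, methoxy or hydroxyl at this place would bring the number back towards that of compound 1 stays open. So does whether chloro, methyl and trifluoromethyl behave the same way elsewhere on this ring.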